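Ethyl to propyl on the limit compound

A few compounds are considered here, and "the series" means these few. Any claim that something is new, unique, unknown or untested is made for them only; others in the source may bear on it.

- compound 1 `CCCc1ccc(CC(C)(Oc2ccc(C(C)C)cc2)C(=O)O)cc1` gives 0.5 mg/kg as a measured number
- compound 2 `CCc1ccc(CC(C)(Oc2ccc(C(C)C)cc2)C(=O)NS(=O)(=O)C(F)(F)F)cc1` gives > 10 mg/kg as a limit

In a functional assay on the whole organism for inhibition, with Rattus norvegicus as the target (a higher number here means that more compound is needed for the effect, a lower number that less compound is needed), compound 2 stands at > 10 mg/kg and this is a limit of the assay, not a number. Compound 3 `CCCc1ccc(CC(C)(Oc2ccc(C(C)C)cc2)C(=O)NS(=O)(=O)C(F)(F)F)cc1` differs from compound 2 by methyl in place of hydrogen on a saturated chain carbon, two bonds along the chain from an aromatic carbon, or 4-ethylphenyl to 4-propylphenyl. Among the compounds with values here, compound 1 also carries 4-propylphenyl and gives 0.5 mg/kg in this assay, which is the only number available to support an expectation. The expected change is an at least 1.6-fold lower number from compound 2 to compound 3 (0.22 log units; that floor lies within the scatter) in this assay, modest in size and towards less compound needed, and another limit remains possible. Compound 3 is estimated at 6 mg/kg, with an expected range from 1.5 mg/kg to 25 mg/kg in this assay for this measurement.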

Compound 3, dose for half-maximal effect: > 10 mg/kg
Compound 3 gave a limit, no number (the forecaster's own chance of this, stated with the estimate: 40%); middle value at least 1.6-fold (0.22 log units) from the limit.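

In this assay, within the data shown here, with 4-propylphenyl held constant, ((trifluoromethyl)sulfonyl)amino in place of hydroxy on a carbonyl carbon gives an at least 20-fold higher number from compound 1 to compound 3 (1.30 log units; beyond the scatter), the only step that can be read so far. For compound 3, > 10 mg/kg is a limit of the assay and not a number. The change from 4-ethylphenyl to 4-propylphenyl cannot be read, because compound 2 and compound 3 both stand at the limit: the limit of > 10 mg/kg in this assay, at which 2 of the 3 values shown sit.

From the compounds shown here alone, how far compound 3 lies from that limit stays open, as does any effect of chain length while ((trifluoromethyl)sulfonyl)amino is present. Also open, going by these compounds, is how a methylsulfonylamino group in place of hydroxy on the carbonyl carbon, or a butyl chain in place of propyl with the hydroxy kept, would read in this assay.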